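Two Substituents on the Imidazole Nitrogen of a Shared Core

A few compounds are considered here, and "the series" means these few. Any claim that something is new, unique, unknown or untested is made for them only; others in the source may bear on it.

Measured compounds:
compound 1, `CN1CCN(c2ccc(Nc3ncc4nc(Nc5ccc(F)cc5)n([C@H]5CCCN(C(=O)CO)C5)c4n3)cc2)CC1`, 1.8 nM
compound 2, `CN1CCN(c2ccc(Nc3ncc4nc(Nc5ccccc5)n([C@H]5CCN(S(C)(=O)=O)C5)c4n3)cc2)CC1`, 17 nM

Compound 1 has the lowest of the two numbers in a functional assay on HCC827 cells (Homo sapiens) for antiproliferative activity, read by MTT assay, with a stated time of 72 h; on this read-out higher numbers stand for weaker inhibition and lower numbers for stronger inhibition; compound 2 stands well above it, and the gap between them is beyond the scatter. The two differ in more than one place, so what separates them cannot be assigned to a single change.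

Compound 3, `CNC(=O)CN1CC[C@H](n2c(Nc3ccc(F)cc3)nc3cnc(Nc4ccc(N5CCN(C)CC5)cc4)nc32)C1`, has not yet been measured in this assay. It differs from compound 1 in one place: 1-((methylcarbamoyl)methyl)pyrrolidin-3-yl in place of 1-((hydroxymethyl)carbonyl)piperidin-3-yl on an aromatic nitrogen. The fluorine-bearing aryl amine of compound 1 is kept. Among the compounds with values here, since no single-point step between measured compounds covers this exchange, the expectation rests on compound 1 alone. Compound 3 is expected to lose a little potency, a step of a 2.2-fold higher number from compound 1 to compound 3 (0.35 log units; beyond the scatter) that is estimated to stay close to the scatter. Compound 3 is therefore expected to give about 4 nM, between 1.2 nM and 15 nM.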

Compound 3, half-maximal inhibitory concentration: 1520 nM
Estimate against measurement, compound 3: 380-fold (2.58 log units) below; measured number above the stated range.
By their numbers in this assay, from the lowest: compound 1; then compound 2; then compound 3.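

In this assay, placing 1-((methylcarbamoyl)methyl)pyrrolidin-3-yl on the aromatic nitrogen in place of 1-((hydroxymethyl)carbonyl)piperidin-3-yl gives an 840-fold higher number from compound 1 to compound 3 (2.93 log units; beyond the scatter), with the rest of the molecule unchanged. The position therefore discriminates sharply between two groups that match in heavy atoms, hydrogen-bond donors and acceptors, and net charge, so those counts alone do not set the potency here. Nothing available explains why this exchange has so large an effect.

The exchange alters the ring size and the chain on the ring nitrogen together, so the share of each in the step remains unresolved. Also open, on these data alone, is how a chain ending in a primary amine or a carboxylic acid would behave on this nitrogen.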